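Methoxy for Fluoro on the Benzyl Ring

A few compounds are considered here, and "the series" means these few. Any claim that something is new, unique, unknown or untested is made for them only; others in the source may bear on it.

Compound 1 `CCOC(=O)[C@H](CCC(=O)O)NC(=O)c1ccc(CNc2nc3cc(N)cc(N)c3nc2-c2ccccc2)cc1` gives < 100000 nM.
Compound 2 `COc1ccc(CNc2nc3cc(N)cc(N)c3nc2-c2ccccc2)cc1OC` gives 66100 nM.
Compound 3 `Nc1cc(N)c2nc(-c3ccccc3)c(NCc3ccc(F)cc3)nc2c1` gives < 100000 nM.

In a functional assay on HOP-92 cells (Homo sapiens) for inhibition, read by sulforhodamine B assay, with a stated time of 48 h (on this read-out lower numbers stand for higher toxicity in this test and higher numbers for lower toxicity in this test), compound 3 stands only at a limit of the assay, < 100000 nM. Compound 1 likewise reaches only a limit, < 100000 nM. Going by the values given here, compound 2 is the one compound with a number, 66100 nM. The step that the limit leaves unreadable from compound 2 to compound 3 therefore cannot be sized, and the reason is the limit of < 100000 nM in this assay, at which 2 of the 3 values shown sit. Compound 4 `COc1ccc(CNc2nc3cc(N)cc(N)c3nc2-c2ccccc2)cc1` differs from compound 3 by methoxy in place of fluoro on an aromatic carbon. Among the compounds with values here, no measured step shows this change on its own, so its size is unknown. Compound 4 is expected to sit near compound 2, at an estimated 70000 nM, within 30000 nM to 150000 nM. The expected step is a step that the limit leaves unreadable from compound 3 to compound 4, with a fair chance that only a limit is reported.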

Compound 4, concentration lethal to 50% of the cells: < 100000 nM
Compound 4 ended at the assay's limit (the forecaster's own chance of this, stated with the estimate: 45%); the middle value lies beyond the limit too.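

In this assay compound 4 gives < 100000 nM, which is a limit and not a number. No step from compound 2 or compound 3 to compound 4 can therefore be read: the limit of < 100000 nM in this assay, at which 3 of the 4 values shown sit.

Going by these compounds, whether compound 3 and compound 4 differ at all, and how either stands against compound 2, remains open.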